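Series notes: propyl in place of hydrogen on compound 3

This account rests on a few compounds, and the source may have more. Where it says the series, first, only, none or still open, it means among the compounds named here.

Measured so far:
compound 1 `COc1ccccc1N1CCN(CCCNc2ccncc2C(=O)N(C)C)CC1` gives 12.6 nM
compound 2 `COc1ccccc1N1CCN(CCCNc2ccccc2C(=O)c2ccccc2)CC1` gives 31.6 nM
compound 3 `CN(C)C(=O)c1cccnc1NCCCN1CCN(c2ccccc2)CC1` gives 6.31 nM

All three numbers come from a functional assay for antagonist activity at Alpha-1A adrenergic receptor (Oryctolagus cuniculus); a higher number here means weaker binding, a lower number tighter binding. Compound 3 has the lowest number of the three. Its nearest neighbour is compound 1, whose number is within the scatter of it, so no order between compound 3 and compound 1 can be read. Compound 2 stands furthest from compound 3, with a number beyond the scatter; of the three, only compound 2 is clearly weaker than compound 3.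

The step now to be followed goes from compound 3 to compound 4 `CCCc1ccccc1N1CCN(CCCNc2ncccc2C(=O)N(C)C)CC1`, which is not yet measured in this assay. The change is propyl in place of hydrogen on an aromatic carbon. Everything else in the shared core stays as it is in compound 3.

Within the data shown here, no measured pair in this set differs in one place, so no step of this kind has been seen here. Compound 1 carries a methoxy where compound 3 carries hydrogen, but the two also differ in the core, so their gap gives only a rough hint. Compound 4 is expected to give 15 nM, with a range of 5 nM to 45 nM. The estimated step of a 2.4-fold higher number from compound 3 to compound 4 (0.38 log units; beyond the scatter) points to a somewhat weaker value, not far outside the scatter.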

Compound 4, dissociation constant: 0.2 nM
Compound 4: the middle estimate sits 75-fold (1.88 log units) above what was measured; the measured number lies below the stated range.
By their numbers in this assay, from the lowest: compound 4; then compounds 3 and 1 (each within the scatter of the next); then compound 2.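

In this assay, among these compounds, the change from phenyl to 2-propylphenyl gives a 32-fold lower number from compound 3 to compound 4 (1.50 log units; beyond the scatter) and is the first step that differs in one place. This aromatic carbon, ortho to a large group, therefore does more than accept a substituent: a propyl group with no hydrogen-bond donors or acceptors and no net charge moves the number sharply lower. The earlier compounds shown here could not show this, as those with methoxy on this ring also differ from compound 3 elsewhere, leaving the contribution of this position unresolved. No measurement among those shown accounts for the size of the step.

Still open, going by these compounds, is whether the effect depends on the propyl chain itself: ethyl, butyl or branched isopropyl at the same carbon would test chain length and shape, while an amine or a carboxylic acid there would test whether a charged group can take its place. Also open, on these data alone, is whether a step of this size carries over to the core of compound 1, which differs from that of compound 3.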